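The source may hold more compounds than are shown below. What is called first, only, known or untested is meant among the compounds shown, and "the series" means these compounds.

Measured so far in a functional assay on K562 cells (Homo sapiens) for cytotoxicity, read by MTT assay, with a stated time of 72 h; on this read-out lower numbers stand for stronger inhibition of growth and higher numbers for weaker inhibition of growth:

Compound 1, `O=C(/N=C(/NC(=O)c1ccno1)[Se]Cc1ccccc1)c1ccno1`: 20000 nM
Compound 2, `O=C(/N=C(/NC(=O)c1cc(-c2ccccc2)nc2ccccc12)[Se]Cc1ccccc1)c1cc(-c2ccccc2)nc2ccccc12`: 9060 nM
Compound 3, `CS/C(=N\C(=O)c1cc(-c2ccccc2)nc2ccccc12)NC(=O)c1cc(-c2ccccc2)nc2ccccc12`: 34400 nM

Compound 3 has the highest number of the three. Against compound 1 the gap is within the scatter, so the two are not separated; against compound 2 the gap is real, a 3.8-fold higher number from compound 2 to compound 3 (0.58 log units; beyond the scatter). The two compounds differ by a group of 2 heavy atoms (1 carbon, 1 sulfur; no ring) in place of a group of 8 heavy atoms (7 carbon, 1 selenium; one six-membered aromatic ring of carbon only), on the carbon with a double bond to nitrogen.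

Compound 4, `C[Se]/C(=N\C(=O)c1cc(-c2ccccc2)nc2ccccc12)NC(=O)c1cc(-c2ccccc2)nc2ccccc12`, is not yet measured. It differs from compound 3 as a group of 2 heavy atoms (1 carbon, 1 selenium; no ring) in place of a group of 2 heavy atoms (1 carbon, 1 sulfur; no ring), on a carbon with a double bond to nitrogen: methylsulfanyl leaves, the selenium analogue enters, on a carbon with a double bond to nitrogen whose other neighbours are two amide-type nitrogens.

Among the compounds with values here, only the step from compound 2 to compound 3 bears on this, and it mixes two alterations at once, so it sets a ceiling rather than a prediction. With the same pair of cores kept, selenium in place of sulfur is expected to move the number downward by a modest amount at most, roughly a 1.7-fold lower number from compound 3 to compound 4 (0.24 log units; within the scatter), and quite possibly within the scatter. Compound 4 is therefore expected at 20000 nM, in the range 8000 nM to 50000 nM.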

Compound 4, concentration for 50% growth inhibition: 5800 nM
Compound 4: middle estimate off by 3.4-fold (0.54 log units), on the high side, and the stated range ends above it.
By their numbers in this assay, from the lowest: compounds 4 and 2 (each within the scatter of the next); then compounds 1 and 3 (each within the scatter of the next).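

In this assay the selenium analogue entering in place of methylsulfanyl, on the carbon with a double bond to nitrogen whose other neighbours are two amide-type nitrogens, gives a 5.9-fold lower number from compound 3 to compound 4 (0.77 log units; beyond the scatter) and so shows that this exchange alone, with the rest of the structure held constant, moves the number beyond the scatter. The earlier step of a 3.8-fold higher number from compound 2 to compound 3 (0.58 log units; beyond the scatter) changed the atom and the group on it together, so it could not show this. Hydrogen in place of phenyl on the saturated chain carbon bound to a selenium atom gives a 1.6-fold lower number from compound 2 to compound 4 (0.19 log units; within the scatter) and stays within the scatter, so among compounds 2, 3 and 4 the larger separation goes with the change from sulfur to selenium and not with the phenyl. Nothing measured here accounts for the difference between the sulfur and selenium compounds.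

The compounds shown leave open whether the same exchange holds with the core of compound 1 or with a benzyl group on sulfur in place of the one on selenium in compound 2. On these data alone, how an ethyl chain on selenium, or an amine on the same carbon, would read also remains open.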